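This account rests on a few compounds, and the source may have more. Where it says the series, first, only, none or still open, it means among the compounds named here.

Measured so far in a functional assay on Ehrlich cells (Mus musculus) for cytotoxicity, read by trypan blue exclusion, with a stated time of 2 h, tested at 25 ug/mL; a lower number here means a weaker effect, a higher number a stronger effect of the compound at the concentration tested:
Compound 1, `CCCCNC(=S)NC1=C(C#N)C(c2ccc(Cl)cc2Cl)C2=C(CCCC2=O)N1c1ccc(S(N)(=O)=O)cc1`, gives 30%.
Compound 2, `N#CC1=C(NC(=S)Nc2ccc(Cl)cc2)N(c2ccc(S(N)(=O)=O)cc2)C2=C(C(=O)CCC2)C1c1ccc(Cl)cc1Cl`, gives 60%.

Among the compounds with values here, compound 2 stands highest of the two numbers in this assay; its nearest neighbour is compound 1, and the one measured step, a number 30 percentage points higher from compound 1 to compound 2 (beyond the scatter), separates them.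

Compound 3, `N#CC1=C(N2C(=O)CCC2=O)N(c2ccc(S(N)(=O)=O)cc2)C2=C(C(=O)CCC2)C1c1ccc(Cl)cc1Cl`, differs from compound 2 in one place: a group of 7 heavy atoms (4 carbon, 1 nitrogen, 2 oxygen; one five-membered non-aromatic ring with 1 hetero atom) in place of a group of 11 heavy atoms (7 carbon, 2 nitrogen, 1 sulfur, 1 chlorine; one six-membered aromatic ring of carbon only), on a double-bonded ring carbon

Within the data shown here, the step from compound 1 to compound 2 is the only measured step and it bears on this change only loosely: it exchanged a butyl for a 4-chlorophenyl on an amide-type nitrogen, whereas the change to compound 3 removes the whole group with two hydrogen-bond donors and puts a 2,5-dioxopyrrolidin-1-yl ring in its place. Among the measured compounds shown here, no measured pair tests that kind of exchange. The account therefore expects for compound 3 a step of a number 18 percentage points lower from compound 2 to compound 3 (beyond the scatter), a drop that may not exceed the scatter. Compound 3 is estimated at 42%, within 20% to 62%.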

Compound 3, a percentage reported as activity, at one concentration (the size of the read-out at that concentration, not a potency): 50%
Compound 3: middle estimate off by 8 percentage points, on the low side; the measured number falls inside the stated range.
By their numbers in this assay, from the lowest: compound 1; then compounds 3 and 2 (each within the scatter of the next).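

In this assay, the 2,5-dioxopyrrolidin-1-yl ring has 0 hydrogen-bond donors and replaces a group with 2 hydrogen-bond donors on the double-bonded ring carbon, giving a number 10 percentage points lower from compound 2 to compound 3 (within the scatter) and so showing that, for this pair, the read-out holds without those donors or the six-membered aromatic ring. The same ring also gives a number 20 percentage points higher from compound 1 to compound 3 (beyond the scatter) when it replaces the ringless group of compound 1, so two quite different groups at this position now stand clear of that butyl-bearing group. No measurement shown here explains either step. The compounds shown leave open how a primary amine or an acetamide would read at this carbon. They also leave open whether the six-membered piperidine-2,6-dione ring would read like the 2,5-dioxopyrrolidin-1-yl ring.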